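This account rests on a few compounds, and the source may have more. Where it says the series, first, only, none or still open, it means among the compounds named here.

Three compounds on a shared core were measured in a functional assay on A549 cells (Homo sapiens) for cytotoxicity, read by MTT assay, with a stated time of 72 h; a higher number here means a weaker inhibitor, a lower number a stronger inhibitor. Compound 1 `O=S(=O)(c1ccccc1)c1nc2ccccc2nc1N1CCCC1` gives 34800 nM. Compound 2 `O=S(=O)(c1ccc(Br)cc1)c1nc2ccccc2nc1N1CCCC1` gives > 50000 nM, which is a limit of the assay and not a number. Compound 3 `O=S(=O)(c1ccc(F)cc1)c1nc2ccccc2nc1N1CCCC1` gives 31100 nM, and it stands level with compound 1, with a 1.1-fold lower number from compound 1 to compound 3 (0.05 log units; within the scatter). Compound 4 `O=S(=O)(c1ccc(F)cc1)c1nc2ccccc2nc1N1CCC(O)CC1` carries 4-hydroxypiperidin-1-yl in place of pyrrolidin-1-yl on an aromatic carbon.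

Among the measured compounds shown here, no measured step touches this group. The steps available change only a substituent elsewhere, namely an at least 1.4-fold higher number from compound 1 to compound 2 (0.15 log units; that floor lies within the scatter), a 1.1-fold lower number from compound 1 to compound 3 (0.05 log units; within the scatter) and an at least 1.6-fold lower number from compound 2 to compound 3 (0.20 log units; that floor lies within the scatter), and none of them is shown to exceed the scatter. They give no direct guide to the size or direction of the new step, so no shift beyond the scatter is expected in this assay, and a result at the limit remains possible. The expected change is a 1.1-fold higher number from compound 3 to compound 4 (0.03 log units; within the scatter). For compound 4 the estimated value is 33000 nM, with an expected range from 11000 nM to 70000 nM.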

Compound 4, half-maximal inhibitory concentration: 20200 nM
Beside the measured number, compound 4's estimate is 1.6-fold (0.21 log units) above it; low and high end bracket the measured number.
By their numbers in this assay, from the lowest: compounds 4, 3 and 1 (each within the scatter of the next). At a limit, above all of these: compound 2.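

Among the compounds shown here, compound 4 gives the first measured step at this place, on an aromatic carbon next to the ring nitrogen: in this assay, 4-hydroxypiperidin-1-yl in place of pyrrolidin-1-yl gives a 1.5-fold lower number from compound 3 to compound 4 (0.19 log units; within the scatter). The earlier steps shown here changed only the substituent on the other aromatic ring, whereas this one shows that a larger six-membered ring carrying a hydroxyl group can stand here and still give a number in this assay, with no shift beyond the scatter. Nothing at hand links this small step to any measured property of either group.

The step changes the ring size and adds the hydroxyl group together, and the compounds shown do not separate the two. As far as these compounds go, what a piperidine without the hydroxyl group, a morpholine or an open-chain amine such as dimethylamino would give at this place remains open.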